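A few compounds are considered here, and "the series" means these few. Any claim that something is new, unique, unknown or untested is made for them only; others in the source may bear on it.

Compound 1 `CCSC(=S)SCC(=O)c1ccccc1`: 5010 nM
Compound 2 `CCSC(=S)SCC(=O)c1ccc(C)cc1`: 3980 nM
Compound 3 `CCSC(=S)SCC(=O)c1ccc(NS(C)(=O)=O)cc1`: not yet measured

In a functional assay on HeLa cells (Homo sapiens) for antiproliferative activity, read by resazurin assay (on this read-out higher numbers stand for weaker inhibition and lower numbers for stronger inhibition), compound 2 gives 3980 nM and compound 1 gives 5010 nM, so compound 2 stands level with compound 1 within the scatter.

The next change is methanesulfonamido in place of methyl on an aromatic carbon. Within the data shown here, only one measured step bears on it, at the same aromatic carbon: a 1.3-fold lower number from compound 1 to compound 2 (0.10 log units; within the scatter). That step is small, and it involves only methyl in place of hydrogen. Among the measured compounds shown here, the data hold no example of a group as large as methanesulfonamido, so they give no direction for the change. No shift beyond the scatter is therefore expected in this assay, though with low confidence. The expected step is a 1.3-fold higher number from compound 2 to compound 3 (0.10 log units; within the scatter). For compound 3 the estimated value is 5000 nM, with an expected range from 1500 nM to 16000 nM.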

Compound 3, half-maximal inhibitory concentration: 39800 nM
Compound 3: middle estimate off by 8.0-fold (0.90 log units), on the low side, and the stated range ends below it.
By their numbers in this assay, from the lowest: compounds 2 and 1 (each within the scatter of the next); then compound 3.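

In this assay, the position on an aromatic carbon para to a group of 9 heavy atoms proves sensitive to what it carries: methanesulfonamido in place of methyl gives a 10-fold higher number from compound 2 to compound 3 (1.00 log units; beyond the scatter), and methanesulfonamido in place of hydrogen gives a 7.9-fold higher number from compound 1 to compound 3 (0.90 log units; beyond the scatter), both beyond the scatter. Hydrogen and methyl had stood level, so those two compounds alone gave no sign that this position could move the read-out, and here it moves towards weaker inhibition. No measurement bears on why methanesulfonamido has this effect.

Which part of the methanesulfonamido group carries the step remains open, and an amine, an acetamido group or a methoxy group on the same carbon would help separate this. Also open, going by these compounds, is whether any group here, such as a halogen or a carboxylic acid, can give a lower number than compound 2 by more than the scatter.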